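The source may report more compounds than this note shows. Statements on the series, on what has been measured and on what is new or still open speak of the compounds shown alone.

In a functional assay on P388 cells (Mus musculus) for cytotoxicity (on this read-out lower numbers stand for stronger inhibition and higher numbers for weaker inhibition), the measured compounds are:
- Compound 1 `Cc1cc(-c2c(F)cc3c(=O)ccn(C4CC4)c3c2F)cc(C)n1` gives 15000 nM
- Compound 2 `Cc1cc(-c2c(F)cc3c(=O)c(Cc4c(O)cccc4O)cn(C4CC4)c3c2F)cc(C)n1` gives 250 nM
- Compound 3 `Cc1cc(-c2c(F)cc3c(=O)c(C(=O)O)cn(C4CC4)c3c2F)cc(C)n1` gives 29000 nM

Compound 3 cannot be told apart from compound 1, since a 1.9-fold higher number from compound 1 to compound 3 (0.29 log units; within the scatter) stays within the scatter. It stands far from compound 2, with a 120-fold higher number from compound 2 to compound 3 (2.06 log units; beyond the scatter) being large.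

Compound 4 `Cc1cc(-c2c(F)cc3c(=O)c(Cc4ncc[nH]4)cn(C4CC4)c3c2F)cc(C)n1` carries (1H-imidazol-2-yl)methyl in place of carboxy on an aromatic carbon. Among the compounds with values here, no imidazole example has been measured. The closest guide is the 2,6-dihydroxybenzyl of compound 2, where a 60-fold lower number from compound 1 to compound 2 (1.78 log units; beyond the scatter) is also large. A clear drop in this assay is therefore expected, though smaller than that one, with an estimated 15-fold lower number from compound 3 to compound 4 (1.16 log units; beyond the scatter). For compound 4 the expected value is 2000 nM, within an estimated range of 300 nM to 13000 nM.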

Compound 4, half-maximal inhibitory concentration: 1100 nM
For compound 4 the middle estimate is 1.8-fold (0.26 log units) above the measured one; the range from low to high includes it.
By their numbers in this assay, from the lowest: compound 2; then compound 4; then compounds 1 and 3 (each within the scatter of the next).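

In this assay, the large gain at this position is not confined to 2,6-dihydroxybenzyl: (1H-imidazol-2-yl)methyl also gives one over hydrogen (a 14-fold lower number from compound 1 to compound 4 (1.13 log units; beyond the scatter)) and over carboxy (a 26-fold lower number from compound 3 to compound 4 (1.42 log units; beyond the scatter)). The two groups are not interchangeable, however, as the step between them lies beyond the scatter (a 4.4-fold higher number from compound 2 to compound 4 (0.64 log units; beyond the scatter)). No evidence available here accounts for these differences. Going by these compounds, whether a simple amine on the same carbon, or a longer chain carrying the imidazole, would keep this gain remains open.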